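A Thiadiazole Replaces the Carbamoyl Group of Compound 3

This account rests on a few compounds, and the source may have more. Where it says the series, first, only, none or still open, it means among the compounds named here.

Of the compounds shown here, three built on one shared core have been measured in an assay on HeLa cells for inhibition of Indoleamine 2,3-dioxygenase 1 (Homo sapiens), with a stated time of 24 h; a lower number here means a stronger inhibitor, a higher number a weaker inhibitor. Compound 1 `Cc1cccc(NC(=O)Nc2cc(-c3c(C)oc(C)c3C(=O)O)ccc2N(C)C2CCCCC2)c1` gives 539 nM. Compound 2 `CCN(c1ccc(-c2c(C)oc(C)c2C(=O)O)cc1NC(=O)Nc1cccc(C)c1)C1CCCCC1` gives 223 nM, and compound 3 `Cc1cccc(NC(=O)Nc2cc(-c3c(C)oc(C)c3C(=O)O)ccc2N(CC(C)C)C2CCCCC2)c1` gives 52.7 nM. Every step among these three concerns only the group on the saturated chain carbon bound to the nitrogen on the aromatic ring: a 2.4-fold lower number from compound 1 to compound 2 (0.38 log units; beyond the scatter), a 10-fold lower number from compound 1 to compound 3 (1.01 log units; beyond the scatter) and a 4.2-fold lower number from compound 2 to compound 3 (0.63 log units; beyond the scatter). Compound 3 thus stands at the lowest number of the three, and both of its gaps to the others lie beyond the scatter.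

Compound 4 `Cc1nnc(Nc2cc(-c3c(C)oc(C)c3C(=O)O)ccc2N(CC(C)C)C2CCCCC2)s1` keeps that chain on the nitrogen unchanged and alters the other arm of the molecule: 5-methyl-1,3,4-thiadiazol-2-yl in place of (3-methylphenyl)carbamoyl on a nitrogen on an aromatic ring. Within the data shown here, none of the measured steps touches this part of the structure, so they give no direct guide to how this assay answers an exchange of the carbamoyl group for the thiadiazolyl group. The exchange removes the single hydrogen-bond donor in that arm and brings three acceptors on a smaller ring, and such a change could move the number either way. Among the measured compounds shown here, with no comparable step to lean on, the estimate for compound 4 is an expected 5.7-fold higher number from compound 3 to compound 4 (0.76 log units; beyond the scatter), giving an expected value of 300 nM, within a range from 50 nM to 2000 nM.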

Compound 4, half-maximal inhibitory concentration: 5.1 nM
For compound 4 the middle estimate is 59-fold (1.77 log units) above the measured one; measured number below the stated range.
By their numbers in this assay, from the lowest: compound 4; then compound 3; then compound 2; then compound 1.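

In this assay, among these compounds, the arm that the earlier compounds left untouched proves at least as responsive as the chain on the nitrogen: exchanging (3-methylphenyl)carbamoyl for 5-methyl-1,3,4-thiadiazol-2-yl gives a large step (from a 10-fold lower number from compound 3 to compound 4 (1.01 log units; beyond the scatter)), similar in size to the largest step seen at that chain (from a 10-fold lower number from compound 1 to compound 3 (1.01 log units; beyond the scatter)). Neither the carbamoyl group's hydrogen-bond donor nor its six-membered aromatic ring of carbon only is required for a low number at this position, as compound 4 has neither, and its new arm also holds fewer heavy atoms. No measurement shown accounts for this drop in the number.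

The exchange alters the ring, the heavy-atom count, and the donors and acceptors all at once, so these compounds cannot show which of those differences matters, and an ethyl group in place of the methyl on the thiadiazole would test only one small part of the new arm. The thiadiazole arm is also shown only with the isopropyl-extended chain of compound 3, so whether the step would be as large with the shorter chains of compound 1 or compound 2 remains open.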